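A few compounds are considered here, and "the series" means these few. Any claim that something is new, unique, unknown or untested is made for them only; others in the source may bear on it.

In a functional assay on U-937 cells (Homo sapiens) for cytotoxicity, read by CCK-8 assay, with a stated time of 72 h (on this read-out lower numbers stand for stronger inhibition and higher numbers for weaker inhibition), compound 3 `C=CCn1c(=O)/c(=C\c2ccc(F)c(Br)c2)[nH]c(=O)/c1=C\c1ccccc1OC` has no single number: compound 3 gives "not active" (no number reported), so it cannot be placed against the others on the same scale. The step to compound 4 `C=CCn1c(=O)/c(=C\c2cccc(C)c2)[nH]c(=O)/c1=C\c1ccccc1OC` is 3-methylphenyl in place of 3-bromo-4-fluorophenyl on a double-bonded chain carbon bound to an aromatic carbon. For the measured compounds named here, only one measured step bears on it, and only loosely: from compound 1 `C=CCn1c(=O)/c(=C\c2ccccc2OC)[nH]c(=O)/c1=C\c1ccccc1OC` to compound 2 `C=CCn1c(=O)/c(=C\c2cccc(Br)c2)[nH]c(=O)/c1=C\c1ccccc1OC` the change was a 4.6-fold lower number from compound 1 to compound 2 (0.67 log units; beyond the scatter), where compound 1 gives 5100 nM and compound 2 gives 1100 nM. That step shows that a group at the 3-position of the phenyl on the double-bonded chain carbon is compatible with a measurable number, while compound 3, with its 3-bromo-4-fluorophenyl, gave none. Compound 4 carries a 3-methylphenyl, which resembles compound 2 more than compound 3, so a measurable number is expected for compound 4, but nothing in these data tells how a methyl compares with a bromine at that position, and a wide range is therefore appropriate. Compound 4 is estimated to give 3000 nM in this assay, expected to lie between 800 nM and 15000 nM, with a real chance that compound 4, like compound 3, returns no number at all.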

Compound 4, half-maximal inhibitory concentration: 5100 nM
Compound 4: the middle estimate sits 1.7-fold (0.23 log units) below what was measured; low and high end bracket the measured number.
By their numbers in this assay, from the lowest: compound 2; then compounds 1 and 4 (each within the scatter of the next).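

In this assay the group on this aromatic carbon clearly matters: with methyl in place of bromo, there is a 4.6-fold higher number from compound 2 to compound 4 (0.67 log units; beyond the scatter) in a step beyond the usual scatter. Swapping the 2-methoxyphenyl for the 3-methylphenyl gives no change at the digits printed from compound 1 to compound 4 (within the scatter) and the two compounds cannot be told apart, so among compounds 1, 2 and 4 the lower number goes with the 3-bromophenyl of compound 2 alone. Compound 3 has no number to set against compound 4, so the step between them cannot be read as a size, and nothing measured here gives a reason why bromo and methyl differ.

Still open, on these data alone, is whether chloro or iodo on that aromatic carbon would follow bromo or methyl, and whether an amine or a carboxylic acid there would give a number at all. Also open, as far as these compounds go, is whether the fluorine of the 3-bromo-4-fluorophenyl alone separates compound 3, which gives no number, from compound 2, or whether a 3-methylphenyl carrying the same fluorine would also give none.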